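This account rests on a few compounds, and the source may have more. Where it says the series, first, only, none or still open, it means among the compounds named here.

Among the compounds with values here, in a toxicity assay on HepG2 cells (Homo sapiens) for inhibition, read by CellTiter-Glo, with a stated time of 48 h (a lower number here means a stronger inhibitor, a higher number a weaker inhibitor), compound 2 `COc1ccc2nc(C)cc(OCC(=O)Nc3ccccc3)c2c1` gives 39800 nM, the only actual number obtained among the compounds tested. Compound 1 `CSc1ccc2nc(C)cc(OCC(=O)Nc3cc(C)cc(C)c3)c2c1` reaches only a limit in this assay, recorded as > 100000 nM, so for it no number exists (the limit of > 100000 nM in this assay, at which 1 of the 2 values shown sits). Compound 3 `COc1ccc2nc(C)cc(OCC(=O)Nc3cc(C)nc(C)n3)c2c1` has not yet been tested; it differs from compound 2 by 2,6-dimethylpyrimidin-4-yl in place of phenyl on an amide-type nitrogen. Within the data shown here, no step between measured compounds is available, so the change is expected to shift the value in this assay little, if at all, perhaps toward weaker inhibition. Compound 3 is therefore estimated at 60000 nM, expected between 20000 nM and 200000 nM, an expected step of a 1.5-fold higher number from compound 2 to compound 3 (0.18 log units; within the scatter) that stays within the scatter.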

Compound 3, half-maximal inhibitory concentration: > 100000 nM
Compound 3 was reported as a limit; the forecaster's own chance of this, stated with the estimate: 45%; middle value at least 1.6-fold (0.22 log units) from the limit.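

In this assay, 2,6-dimethylpyrimidin-4-yl in place of phenyl on the amide-type nitrogen gives an at least 2.5-fold higher number from compound 2 to compound 3 (0.40 log units; beyond the scatter), so the value does respond to a change at this position, here toward weaker inhibition. Compound 3 gives > 100000 nM, which is a limit and not a number, so the full size of the step cannot be read. Such limits are common among these compounds: the limit of > 100000 nM in this assay, at which 2 of the 3 values shown sit.

Whether the ring nitrogens or the methyl groups of the new group account for the step stays open. So does the outcome with a pyridin-3-yl or cyclohexyl group on this nitrogen.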